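A few compounds are considered here, and "the series" means these few. Any claim that something is new, unique, unknown or untested is made for them only; others in the source may bear on it.

Working notes on the series.

Three compounds are measured. Compound 1 `COc1cccc(-c2n[nH]c(-c3cc(C)ccc3C)n2)c1`, compound 2 `COc1cccc(-c2n[nH]c(-c3cc(OC)ccc3C)n2)c1` and compound 3 `COc1ccccc1-c1n[nH]c(-c2ccccc2C)n1` share the same core and differ in the substituents on the two outer rings. In a functional assay on the whole organism (Cricetulus griseus) with Cricetinae gen. sp. as the target (on this read-out higher numbers stand for an effect only at larger amounts of compound and lower numbers for an effect already at smaller amounts), compound 1 gives 2.5 mg/kg. In this assay compound 2 gives 1 mg/kg. In this assay compound 3 gives 0.5 mg/kg, the lowest number of the three, though its gap to compound 2 is within the scatter.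

One single-point change is measured: a 2.5-fold higher number from compound 2 to compound 1 (0.40 log units; beyond the scatter), where (methyl in place of methoxy on an aromatic carbon). The difference between compound 2 and compound 3 is not broken down here.

Compound 4 `Cc1ccccc1-c1n[nH]c(-c2ccccc2C)n1` has not been measured. It is reached from compound 3 by the same kind of change, (methyl in place of methoxy on an aromatic carbon). The surroundings differ: in compound 2 to compound 1 the place is meta to a large group and para to a methyl group, whereas in compound 3 to compound 4 it is ortho to a large group. For the measured compounds named here, only one earlier instance of this kind of change exists, so the expectation rests on that step alone. An expected step of a 2.5-fold higher number from compound 3 to compound 4 (0.40 log units; beyond the scatter) is taken, due to a 2.5-fold higher number from compound 2 to compound 1 (0.40 log units; beyond the scatter). Compound 4 is therefore estimated at 1.25 mg/kg in this assay, expected between 0.5 mg/kg and 3 mg/kg.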

Compound 4, dose for half-maximal effect: 0.7 mg/kg
Compound 4: the middle estimate sits 1.8-fold (0.25 log units) above what was measured; the measured number falls inside the stated range.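

In this assay, methyl in place of methoxy at the place ortho to a large group gives a 1.4-fold higher number from compound 3 to compound 4 (0.15 log units; within the scatter), a step that stays within the scatter. Set beside the earlier instance of the same change, this step does not differ from it beyond what two such steps allow: the same change on two cores in this assay, a 2.5-fold higher number (0.40 log units; beyond the scatter) from compound 2 to compound 1 and a 1.4-fold higher number (0.15 log units; within the scatter) from compound 3 to compound 4, 1.8-fold (0.25 log units) apart, within the scatter of two such steps. For the compounds shown here, the two cores therefore give no sign that the change behaves differently from one to the other, but with only two steps, one beyond the scatter and one within it, this shows neither a fixed size for the change nor that its surroundings are without influence.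

The compounds shown leave open how the change behaves at other places on the two outer rings and on further cores of the series. They also leave open what a different group would do at the same aromatic carbon, such as a hydroxyl, an amine, a carboxylic acid or a longer alkoxy chain.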